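Cyano in Place of Methoxy on the Amide Phenyl

The compounds below may be only part of what the source reports. "The series", "measured", "known", "first", "only" and "open" are said of these compounds alone.

In a functional assay on A549 cells (Homo sapiens) for inhibition, read by CCK-8 assay, with a stated time of 72 h, tested at 10 uM (on this read-out higher numbers stand for more inhibition of growth at the one concentration tested and lower numbers for less inhibition of growth), compound 2 `COc1ccc(NC(=O)C2(C(=O)Nc3ccc(Nc4ncc5cc(C(=O)N(C)C)n(C6CCCC6)c5n4)cc3)CC2)cc1` gives 78.5%. Compound 1 `Cc1cccc(NC(=O)C2(C(=O)Nc3ccc(Nc4ncc5cc(C(=O)N(C)C)n(C6CCCC6)c5n4)cc3)CC2)c1` gives 86.1% and compound 3 `Cc1ccc(NC(=O)C2(C(=O)Nc3ccc(Nc4ncc5cc(C(=O)N(C)C)n(C6CCCC6)c5n4)cc3)CC2)cc1` gives 90.6%, so compound 2 sits at the bottom of the three numbers in hand, separated from compound 3 by a number 12.1 percentage points higher from compound 2 to compound 3 (beyond the scatter) but from compound 1 only by a number 7.6 percentage points lower from compound 1 to compound 2 (within the scatter). Compound 4 `CN(C)C(=O)c1cc2cnc(Nc3ccc(NC(=O)C4(C(=O)Nc5ccc(C#N)cc5)CC4)cc3)nc2n1C1CCCC1` carries cyano in place of methoxy on an aromatic carbon. Among the measured compounds shown here, no measured step brings in a cyano group; the only step touching this carbon, a number 12.1 percentage points higher from compound 2 to compound 3 (beyond the scatter), is modest, and the other step, a number 7.6 percentage points lower from compound 1 to compound 2 (within the scatter), is within the scatter. A small change is therefore expected in this assay, likely upward but not clearly beyond the scatter, a number 4.5 percentage points higher from compound 2 to compound 4 (within the scatter). Compound 4 is estimated at 83%, with a range from 70% to 93%.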

Compound 4, percent growth inhibition at one concentration: 95%
The estimate for compound 4 lay 12 percentage points below the measured number, and the stated range ends below it.
By their numbers in this assay, from the lowest: compounds 2, 1, 3 and 4 (each within the scatter of the next, the first and the last beyond it).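

At the position para to a large group, cyano, like methyl in compound 3, stands clear of methoxy in this assay: a number 16.5 percentage points higher from compound 2 to compound 4 (beyond the scatter). Against the two methyl-bearing compounds nothing separates it, since a number 4.4 percentage points higher from compound 3 to compound 4 (within the scatter) and a number 8.9 percentage points higher from compound 1 to compound 4 (within the scatter) both lie within the scatter, so replacing methyl with cyano gives no readable gain. No measurement at hand explains the step away from methoxy.

Going by these compounds, whether an amine, a hydroxyl or a carboxylic acid in this place would keep growth inhibition at this level remains open. So does the outcome for a halogen such as chlorine.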